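The source may report more compounds than this note shows. Statements on the series, on what has been measured and on what is new or still open speak of the compounds shown alone.

Measured so far in a physicochemical assay for solubility, at pH 7.4; on this read-out higher numbers stand for higher solubility and lower numbers for lower solubility:

- Compound 1 `NS(=O)(=O)c1ccc(S(=O)(=O)CCCO)s1` gives 14600 ug/mL
- Compound 2 `CC(=O)OCCCc1ccc(S(N)(=O)=O)cc1` gives 1600 ug/mL

Compound 2 holds the lower of these two numbers, and its gap to compound 1 lies beyond the usual scatter. Compound 3 `CC(=O)OCCCCc1ccc(S(N)(=O)=O)cc1` differs from compound 2 in one place acetoxymethyl in place of acetoxy on a saturated chain carbon, three bonds along the chain from an aromatic carbon with acetoxymethyl in place of acetoxy on a saturated chain carbon, three bonds along the chain from an aromatic carbon. Among the compounds with values here, no measured pair shows this change, so any expectation is rough. A small move to a lower number is expected in this assay and may barely clear the scatter. The estimated step is a 2.0-fold lower number from compound 2 to compound 3 (0.30 log units; within the scatter) in round terms. Compound 3 is expected at 800 ug/mL with an estimated range from 300 ug/mL to 1800 ug/mL for the coming measurement.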

Compound 3, solubility: 800 ug/mL
The estimate for compound 3 equals the measured number at the digits printed; the measured number falls inside the stated range.
By their numbers in this assay, from the lowest: compounds 3 and 2 (each within the scatter of the next); then compound 1.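

Within the data shown here, the first matched pair in this assay puts acetoxymethyl in place of acetoxy on a saturated chain carbon, three bonds along the chain from an aromatic carbon, and gives a 2.0-fold lower number from compound 2 to compound 3 (0.30 log units; within the scatter). At this position, then, this change leaves the two numbers no further apart than repeat measurements of one compound can be. Nothing measured here offers an explanation for the result. Still open, on these data alone, is whether a longer chain would give a step beyond the scatter, and whether an amine or a carboxylic acid in place of the acetoxy group would do so.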